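Swapping Methyl for Nitro on the Aromatic Ring

The compounds below may be only part of what the source reports. "The series", "measured", "known", "first", "only" and "open" are said of these compounds alone.

Compound 1 `NCC(=O)NCc1nnc(-c2ccccc2)o1` gives 155 nM in an assay for inhibition of histone deacetylase 8 (Homo sapiens), read by fluorescence, with a stated time of 15 min; on this read-out lower numbers stand for stronger inhibition and higher numbers for weaker inhibition. Compound 2 `Cc1ccc(-c2nnc(CNC(=O)CN)o2)cc1` gives 139 nM, and compound 3 `Cc1ccc(-c2nnc(CNC(=O)[C@@H](C)N)o2)cc1` gives 121 nM. Compound 3 thus carries the lowest of the three numbers, but its gap to compound 2 and to compound 1 lies within the scatter, so no order among the three can be read from these values. Compound 4 `C[C@@H](N)C(=O)NCc1nnc(-c2ccc([N+](=O)[O-])cc2)o1` differs from compound 3 by nitro in place of methyl on an aromatic carbon. Among the compounds with values here, the only measured step that touches the same aromatic carbon is a 1.1-fold lower number from compound 1 to compound 2 (0.05 log units; within the scatter), which stayed within the scatter; the step of a 1.1-fold lower number from compound 2 to compound 3 (0.06 log units; within the scatter) concerns the chain carbon and was likewise within the scatter. Within the data shown here, no measured step introduces a nitro group, so these data offer no basis for a change beyond the scatter in this assay. Compound 4 is therefore expected to give 125 nM, with a range of 50 nM to 320 nM. The expected step is a 1.0-fold higher number from compound 3 to compound 4 (0.01 log units; within the scatter).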

Compound 4, half-maximal inhibitory concentration: 127 nM
Beside the measured number, compound 4's estimate is 1.0-fold (0.01 log units) below it, and the stated range covers the measured number.
By their numbers in this assay, from the lowest: compounds 3, 4, 2 and 1 (each within the scatter of the next).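

In this assay, the exchange of methyl for nitro on an aromatic carbon para to a large group gives a 1.0-fold higher number from compound 3 to compound 4 (0.02 log units; within the scatter), so a group of three heavy atoms with two hydrogen-bond acceptors takes the place of a single carbon without the number leaving the scatter. Earlier, this position had shown only methyl in place of hydrogen, with a 1.1-fold lower number from compound 1 to compound 2 (0.05 log units; within the scatter); it has now held three different groups, and neither step goes beyond the scatter. No measured information accompanies this result to explain it. As far as these compounds go, whether an amine or a carboxylic acid at this aromatic carbon would also stay within the scatter remains open. So does the effect of a longer chain on the saturated chain carbon, which among these compounds carries only hydrogen or methyl.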